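The source may hold more compounds than are shown below. What is called first, only, known or untested is meant among the compounds shown, and "the series" means these compounds.

Measured so far, in an assay on isolated protein for activation of Insulin-degrading enzyme (Homo sapiens), read by fluorescence, with stated times of 10 min and 20 min; on this read-out higher numbers stand for an effect only at larger amounts of compound and lower numbers for an effect already at smaller amounts:

compound 1 `O=C(CCCc1c[nH]c2ccccc12)NCCCn1ccnc1` gives 10000 nM; 89100 nM (2 entries)
compound 2 `O=C(CCCc1cn(S(=O)(=O)c2ccccc2F)c2ccccc12)NCCCn1ccnc1` gives 7940 nM
compound 3 `O=C(CCCc1cn(S(=O)(=O)c2cccc(F)c2)c2ccccc12)NCCCn1ccnc1` gives 10200 nM

Compound 2 has the lowest single number of the two compounds with one entry each; its nearest neighbour is compound 3, and the step of a 1.3-fold higher number from compound 2 to compound 3 (0.11 log units; within the scatter) stays within the usual scatter. Compound 1, which carries no sulfonyl group on the shared core, was measured more than once, and the spread of its repeats the several entries of compound 1 in this assay, 10000 nM; 89100 nM (2 entries) shows how far two readings of the same compound can lie apart here.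

The compound not yet measured is compound 4 `O=C(CCCc1cn(S(=O)(=O)c2cccnc2)c2ccccc12)NCCCn1ccnc1`. It differs from compound 2 in one place: pyridin-3-yl in place of 2-fluorophenyl on a sulfonyl sulfur. Among the measured compounds shown here, the only measured step that touches the group on the sulfonyl sulfur is the move from compound 2 to compound 3, where shifting the fluorine on the phenyl ring did not move the number beyond the scatter. For the measured compounds named here, no measured step swaps the phenyl ring itself for a pyridinyl ring, so the expectation rests on that one neighbouring step alone.

For compound 4 the expected step of a 1.3-fold higher number from compound 2 to compound 4 (0.10 log units; within the scatter) is therefore small and not beyond the scatter. Compound 4 is estimated at 10000 nM, within a range from 4000 nM to 30000 nM.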

Compound 4, half-maximal effective concentration: 26900 nM
Beside the measured number, compound 4's estimate is 2.7-fold (0.43 log units) below it; the range from low to high includes it.
By their numbers in this assay, from the lowest: compounds 2 and 3 (each within the scatter of the next); then compound 4.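

Swapping the whole ring on the sulfonyl sulfur has an effect that moving the fluorine did not: the change gives a 3.4-fold higher number from compound 2 to compound 4 (0.53 log units; beyond the scatter), and measured against the other fluorinated compound it gives a 2.6-fold higher number from compound 3 to compound 4 (0.42 log units; beyond the scatter). A higher number means that more compound is needed for the same effect, so among these three compounds pyridin-3-yl reads worse than either fluorophenyl group, which shows that this position is not indifferent to what sits on it. Both steps are modest, however, and two readings of one compound can lie further apart than either step, as seen in the repeats of the unsulfonylated parent: the several entries of compound 1 in this assay, 10000 nM; 89100 nM (2 entries)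

The compounds shown cannot separate the gain of the ring nitrogen from the loss of the fluorine, and a plain phenyl ring on the sulfonyl sulfur would be the group to tell these two apart. They also leave open how a small alkyl group such as methyl, or a phenyl ring carrying an amine or a carboxylic acid, would read at this position.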